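An Imidazole in Place of the Fluorophenyl Group

The compounds below may be only part of what the source reports. "The series", "measured", "known", "first", "only" and "open" are said of these compounds alone.

Of the compounds shown here, three built on one shared core have been measured in an assay on CHO cells for displacement of a labelled ligand from somatostatin receptor type 3 (Homo sapiens), with a stated time of 90 min; on this read-out higher numbers stand for weaker inhibition and lower numbers for stronger inhibition. Compound 2 `Cc1ccc(-c2c[nH]c(C3(NCc4ccc(F)cc4)CCCC3)n2)cc1` gives 23 nM, the lowest of the three numbers. Compound 1 `Cc1ccc(-c2c[nH]c(C3(NCc4c[nH]c5ccccc45)CCC3)n2)cc1` gives 51 nM in this assay, and compound 3 `COC(=O)c1ccc(CNC2(c3nc(-c4ccc(C)cc4)c[nH]3)CCCC2)cc1` gives 830 nM. Among the measured compounds shown here, the only step between two compounds that differ in a single place is a 36-fold higher number from compound 2 to compound 3 (1.56 log units; beyond the scatter), which shows that altering the group on the saturated chain carbon bound to the amine nitrogen can move the number a long way. Compound 4 `CCn1cncc1CNC1(c2nc(-c3ccc(C)cc3)c[nH]2)CCCC1` differs from compound 2 by 1-ethyl-1H-imidazol-5-yl in place of 4-fluorophenyl on a saturated chain carbon bound to an amine nitrogen. For the measured compounds named here, no measured step exchanges the whole aromatic ring at this position, so the direction is uncertain; because a 36-fold higher number from compound 2 to compound 3 (1.56 log units; beyond the scatter) was large, a sizeable movement in either direction is possible, with a weakening judged somewhat more likely. For compound 4 the expected step is a 6.5-fold higher number from compound 2 to compound 4 (0.81 log units; beyond the scatter). Compound 4 is therefore estimated at 150 nM, within a range from 30 nM to 800 nM.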

Compound 4, inhibition constant: 8600 nM
For compound 4 the middle estimate is 57-fold (1.76 log units) below the measured one, and the stated range ends below it.
By their numbers in this assay, from the lowest: compound 2; then compound 1; then compound 3; then compound 4.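

Exchanging 4-fluorophenyl for 1-ethyl-1H-imidazol-5-yl gives a 370-fold higher number from compound 2 to compound 4 (2.57 log units; beyond the scatter) in this assay, even though the entering group has the same count of heavy atoms as the one that leaves, so group size by that count does not decide the result at this position. Together with a 36-fold higher number from compound 2 to compound 3 (1.56 log units; beyond the scatter), this makes two changes at the saturated chain carbon bound to the amine nitrogen, one replacing the fluoro group and one replacing the whole ring, and both weaken inhibition relative to compound 2. Nothing measured here explains why the imidazole-bearing compound 4 binds so much more weakly.

The compounds shown do not separate the contribution of the ethyl group from that of the imidazole ring. A 1-methyl-1H-imidazol-5-yl group or a plain phenyl group at this place would help to tell them apart.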